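The compounds below may be only part of what the source reports. "The series", "measured", "known", "first", "only" and "open" are said of these compounds alone.

Working notes on the series. For the measured compounds named here, in a functional assay on HEL cells (Homo sapiens) (a lower number here means that less compound is tolerated, a higher number that more compound is tolerated), compound 1 `O=C1c2ccccc2N(Cc2ccccc2)S(=O)(=O)N1Cc1ccc(Cl)cc1` gives 20000 nM, the lowest number of the three measured members. Compound 2 `O=S1(=O)N=C(OCc2ccccc2)c2ccccc2N1Cc1ccc(Cl)c(Cl)c1` gives 200000 nM in this assay, and compound 3 `C#CCOCN1c2ccccc2C(=O)N(Cc2ccccc2)S1(=O)=O` gives 140000 nM; both of those numbers lie above that of compound 1 by more than the usual scatter, so compound 1 is the least tolerated of the three on the numbers shown.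

The next step goes from compound 1 to compound 4 `O=C1c2ccccc2N(Cc2ccccc2)S(=O)(=O)N1COCc1ccccc1`, which is not yet measured in this assay. The change is benzyloxy in place of 4-chlorophenyl on a saturated chain carbon bound to an amide-type nitrogen in a ring. Going by the values given here, no step between two measured compounds that differ in just one place is available, so the expectation rests on the numbers alone. Compound 3 carries a related ether-bearing substituent on the same kind of nitrogen and, in this assay, gives a higher number than compound 1, which points to the expected step being upward in this assay, of a size between the scatter and the gap from compound 1 to compound 3.

For compound 4 the estimate in this assay is 60000 nM, with a range of 20000 nM to 200000 nM, the expected step being a 3.0-fold higher number from compound 1 to compound 4 (0.48 log units; beyond the scatter).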

Compound 4, minimum cytotoxic concentration: 49000 nM
Compound 4: the middle estimate sits 1.2-fold (0.09 log units) above what was measured, and the stated range covers the measured number.
By their numbers in this assay, from the lowest: compound 1; then compound 4; then compounds 3 and 2 (each within the scatter of the next).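

For the compounds shown here, this is the first change that can be read at a single place: in this assay, benzyloxy in place of 4-chlorophenyl on a saturated chain carbon bound to an amide-type nitrogen in a ring gives a 2.5-fold higher number from compound 1 to compound 4 (0.39 log units; beyond the scatter) and so a modest move beyond the scatter. The position therefore responds to this change with the rest of compound 1 held constant, and 4-chlorobenzyl to (benzyloxy)methyl moves the number upward. No measurement on hand explains the step.

The change removes the chlorine and brings in the oxygen together, so the share of each stays unresolved. As far as these compounds go, how an amine or a carboxylic acid on the same chain carbon, or a longer chain carrying the phenyl ring, would read at this position also stays open.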